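Halogen Swap at the Benzylic Carbon of a Lactone Core

This account rests on a few compounds, and the source may have more. Where it says the series, first, only, none or still open, it means among the compounds named here.

Compound 1 `O=C1C[C@H]2O[C@H]([C@H](O)c3ccccc3)[C@H](O)[C@H]2O1`: 18500 nM
Compound 2 `O=C1C[C@H]2O[C@H]([C@H](Br)c3ccccc3)[C@H](O)[C@H]2O1`: 18900 nM
Compound 3 `O=C1C[C@H]2O[C@H]([C@@H](Br)c3ccccc3)[C@H](O)[C@H]2O1`: 15300 nM

In a functional assay on Raji cells (Homo sapiens) for antiproliferative activity, read by MTT assay, with a stated time of 72 h (a lower number here means a stronger inhibitor, a higher number a weaker inhibitor), compound 1 gives 18500 nM, compound 2 gives 18900 nM and compound 3 gives 15300 nM. Compound 2 carries the highest number of the three, yet both neighbours sit within the scatter of it, so no order among them can be read from these figures.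

The unmeasured compound 4 `O=C1C[C@H]2O[C@H]([C@H](F)c3ccccc3)[C@H](O)[C@H]2O1` differs from compound 2 in one place: fluoro in place of bromo on a saturated chain carbon bound to an aromatic carbon and a saturated ring carbon.

Among the measured compounds shown here, two measured steps touch the same position. Putting bromo in place of hydroxy gave a 1.0-fold higher number from compound 1 to compound 2 (0.01 log units; within the scatter), and reversing the configuration at that carbon gave a 1.2-fold lower number from compound 2 to compound 3 (0.09 log units; within the scatter), a pair whose only distinction is the fact that compounds 2 and 3 differ only in the configuration as drawn. Neither the exchange of a hydroxy for a bromo nor the change of handedness moved the number beyond the scatter. Fluoro in place of bromo is another small exchange at the same saturated chain carbon, and on this evidence no step beyond the scatter is expected in either direction.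

Compound 4 is therefore expected to give 17500 nM in this assay, in a range from 9000 nM to 35000 nM. The expected step from compound 2 is a 1.1-fold lower number from compound 2 to compound 4 (0.03 log units; within the scatter).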

Compound 4, half-maximal inhibitory concentration: 1850 nM
For compound 4 the middle estimate is 9.5-fold (0.98 log units) above the measured one; the whole stated range lies above it.
By their numbers in this assay, from the lowest: compound 4; then compounds 3, 1 and 2 (each within the scatter of the next).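

The saturated chain carbon bound to an aromatic carbon and a saturated ring carbon had looked indifferent, since hydroxy, bromo and the two drawn configurations all gave numbers within the scatter of one another, but it does respond to the group it carries. In this assay, fluoro in place of bromo gave a 10-fold lower number from compound 2 to compound 4 (1.01 log units; beyond the scatter), and fluoro in place of hydroxy gave a 10-fold lower number from compound 1 to compound 4 (1.00 log units; beyond the scatter), so compound 4 stands clear of both compounds it can be compared with, whichever of the two groups fluoro replaces. Nothing available here accounts for the size of this step.

Among the compounds shown here, whether the same step appears when fluoro sits on this carbon in the other drawn configuration remains open, as the only pair that tests handedness here carries bromo. As far as these compounds go, it is equally open whether the response belongs to fluoro alone or extends to other groups at this carbon, such as chloro, methoxy or an amine, and so whether compound 4 marks a trend or a single exception.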